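The source may hold more compounds than are shown below. What is called first, only, known or untested is meant among the compounds shown, and "the series" means these compounds.

Working notes on the series. For the measured compounds named here, compound 3 `Nc1scc(-c2ccccc2F)c1C(=O)c1ccc(Cl)cc1` stands highest of the three numbers so far in a functional assay on CHO cells for agonist activity at adenosine receptor A1 (Homo sapiens), read by fluorescence and ERK phosphorylation, with stated times of 30 min and 1.5 h, tested at 10 uM; a higher number here means a stronger effect of the compound at the concentration tested, a lower number a weaker effect: compound 3 gives 87%. Compound 1 `Nc1scc(-c2ccccc2F)c1C(=O)c1ccccc1` gives 68%, and compound 2 `COc1ccc(-c2csc(N)c2C(=O)c2ccccc2)cc1` gives 52%. Going by the values given here, the one step between compounds that differ in a single place is a number 19 percentage points higher from compound 1 to compound 3 (beyond the scatter), which concerns the ring on the carbonyl side and not the ring that changes here.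

Compound 4 `Nc1scc(-c2ccc(Br)cc2)c1C(=O)c1ccc(Cl)cc1` is not yet measured. It differs from compound 3 as follows: 4-bromophenyl in place of 2-fluorophenyl on an aromatic carbon. No measured step covers this kind of exchange; compounds 1 and 2 carry different groups at that same place, and their values in this assay are shown above without a computed step. The expectation for compound 4 is therefore a step of a number 9 percentage points lower from compound 3 to compound 4 (within the scatter), not clearly beyond the scatter. Compound 4 is estimated at 78%, within 55% to 95%.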

Compound 4, a percentage reported as activity, at one concentration (the size of the read-out at that concentration, not a potency): 46%
The estimate for compound 4 lay 32 percentage points above the measured number, and the stated range ends above it.
By their numbers in this assay, from the lowest: compounds 4 and 2 (each within the scatter of the next); then compound 1; then compound 3.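

In this assay, for the compounds shown here, 4-bromophenyl in place of 2-fluorophenyl on this aromatic carbon gives a number 41 percentage points lower from compound 3 to compound 4 (beyond the scatter), the first measured step at this position, and it is large. The read-out at this position therefore depends strongly on the aryl group it carries, at least with the 4-chlorophenyl ketone kept constant. Nothing shown gives a reason for this drop.

The halogen and its place on the phenyl ring change together here, and the compounds shown do not separate the two. Also open, going by these compounds, is how 4-fluorophenyl, 2-bromophenyl or a phenyl bearing an amine would read out on this core.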